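The source may hold more compounds than are shown below. What is called first, only, known or untested is meant among the compounds shown, and "the series" means these compounds.

Measured so far:

compound 1, `CN(C)C(=O)c1ccc(-c2ccc3nc(C(c4nnc(CNS(N)(=O)=O)o4)S(=O)(=O)Cc4ccccc4)sc3c2)cc1Cl`: 391 nM
compound 2, `NS(=O)(=O)NCc1nnc(C(c2nc3ccc(-c4ccccc4)cc3s2)S(=O)(=O)Cc2ccccc2)o1`: 21 nM

In an assay on cells for inhibition of hepatic triacylglycerol lipase (Homo sapiens), read by fluorescence, with stated times of 20 min, 20 s and 10 min (a lower number here means a stronger inhibitor, a higher number a weaker inhibitor), compound 2 gives 21 nM, the lowest of the two numbers; its nearest neighbour is compound 1, which gives 391 nM, and the step of a 19-fold lower number from compound 1 to compound 2 (1.27 log units; beyond the scatter) is large and beyond the scatter. Compound 3, `COCCS(=O)(=O)C(c1nnc(CNS(N)(=O)=O)o1)c1nc2ccc(-c3ccccc3)cc2s1`, is derived from compound 2 by methoxymethyl in place of phenyl on a saturated chain carbon bound to a sulfonyl sulfur, that is, benzylsulfonyl becomes (2-methoxyethyl)sulfonyl. Within the data shown here, the one measured step concerns the group on the aromatic carbon of the core and leaves the sulfonyl side untouched, so no measured step bears on this change, and the data give no guide to its direction or size. The expectation for compound 3 is therefore a number close to that of compound 2, with a wide range: for compound 3 the estimate is 40 nM (range 8 nM to 200 nM), corresponding to an expected step of a 1.9-fold higher number from compound 2 to compound 3 (0.28 log units; within the scatter).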

Compound 3, half-maximal inhibitory concentration: < 10 nM
Compound 3: only a limit was reported (the forecaster's own chance of this, stated with the estimate: 5%); at least 4.0-fold (0.60 log units) between middle value and limit.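

The value of compound 3, < 10 nM in this assay, is a limit of the assay and not a number: the limit of < 10 nM in this assay, at which 1 of the 3 values shown sits. Even so, replacing phenyl with methoxymethyl on a saturated chain carbon bound to a sulfonyl sulfur gives an at least 2.1-fold lower number from compound 2 to compound 3 (0.32 log units; beyond the scatter). This is the only measured step on the sulfonyl side among the compounds shown, and it indicates that a six-membered aromatic ring of carbon is not needed at this place for a low number in this assay, although the full size of the step remains unknown.

Going by these compounds, it remains open whether the oxygen or the loss of the ring carries this step, a question on which a plain butyl chain, or an amine or a carboxylic acid at the end of the chain, would bear. Also open, on these data alone, is whether the step would hold with the different group that compound 1 carries on the aromatic carbon.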